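Swapping the dichlorophenyl of compound 3 for methoxyphenyl

The source may report more compounds than this note shows. Statements on the series, on what has been measured and on what is new or still open speak of the compounds shown alone.

Compound 3 `COc1ccc2ncc(S(=O)(=O)c3ccc(Cl)c(Cl)c3)c(N3CCC(C)CC3)c2c1` gives 87% in an assay on isolated protein for displacement of a labelled ligand from metabotropic glutamate receptor 5 (Homo sapiens), with a stated time of 60 min, tested at 1 uM (on this read-out higher numbers stand for more inhibition at the one concentration tested (going by the name of the read-out) and lower numbers for less inhibition), the highest of the three numbers measured. Compound 1 `COc1ccc2ncc(S(=O)(=O)c3ccc(OC)c(Cl)c3)c(N3CCC(C)CC3)c2c1` gives 21% and compound 2 `COc1ccc(S(=O)(=O)c2cnc3ccc(C)cc3c2N2CCC(C)CC2)cc1` gives 62%. Within the data shown here, the one step between single-change neighbours is a number 66 percentage points higher from compound 1 to compound 3 (beyond the scatter). Compound 4 `COc1ccc(S(=O)(=O)c2cnc3ccc(OC)cc3c2N2CCC(C)CC2)cc1` differs from compound 3 by 4-methoxyphenyl in place of 3,4-dichlorophenyl on a sulfonyl sulfur. Compound 1 and compound 2 both carry a methoxy on that aryl ring and sit well below compound 3, so a step downward beyond the scatter is expected here, estimated as a number 49 percentage points lower from compound 3 to compound 4 (beyond the scatter). Because compound 1 gives 21% while compound 2 gives 62%, the estimate for compound 4 is placed between them at 38%, with a range from 12% to 65%.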

Compound 4, a percentage reported as inhibition, at one concentration (the size of the read-out at that concentration, not a potency): 41%
Beside the measured number, compound 4's estimate is 3 percentage points below it, and the stated range covers the measured number.
By their numbers in this assay, from the lowest: compound 1; then compound 4; then compound 2; then compound 3.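

In this assay, 4-methoxyphenyl in place of 3,4-dichlorophenyl on the sulfonyl sulfur gives a number 46 percentage points lower from compound 3 to compound 4 (beyond the scatter), a large loss. With 4-methoxyphenyl kept, the other end of the molecule also counts: methoxy in place of methyl on an aromatic carbon gives a number 21 percentage points lower from compound 2 to compound 4 (beyond the scatter) as a modest step. Hydrogen in place of chloro gives a number 20 percentage points higher from compound 1 to compound 4 (beyond the scatter), so on a methoxy-bearing ring this chloro goes with a lower number.

Nothing available explains these steps. Going by these compounds, whether trifluoromethyl or fluoro on the aryl ring would hold the number up remains open.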